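A few compounds are considered here, and "the series" means these few. Any claim that something is new, unique, unknown or untested is made for them only; others in the source may bear on it.

Compound 1 `COc1ccc(/C=C\C(=O)O)c(OCc2cn(-c3ccc(NC(=O)c4ccccc4)cc3)nn2)c1CC=C(C)C`: 20300 nM
Compound 2 `COc1ccc(/C=C\C(=O)O)c(OCc2cn(-c3ccccc3)nn2)c1CC=C(C)C`: 32300 nM

In a functional assay on COLO 205 cells (Homo sapiens) for cytotoxicity, read by MTT assay, with a stated time of 24 h (on this read-out higher numbers stand for weaker inhibition and lower numbers for stronger inhibition), compound 2 and compound 1 sit within the usual scatter of each other, so neither can be called the stronger. Among the compounds with values here, the only measured step, a 1.6-fold higher number from compound 1 to compound 2 (0.20 log units; within the scatter), touches a group on the same aromatic ring that changes here, and it tells only that such a change can pass without effect. Compound 3 `COc1ccc(/C=C\C(=O)O)c(OCc2cn(-c3nc4ccccc4s3)nn2)c1CC=C(C)C` carries 1,3-benzothiazol-2-yl in place of phenyl on an aromatic nitrogen. Within the data shown here, no measured step covers this kind of swap, so no direction can be expected beyond the scatter. Compound 3 is therefore expected near 26000 nM, between 8000 nM and 85000 nM, a step of a 1.2-fold lower number from compound 2 to compound 3 (0.09 log units; within the scatter) being the estimate.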

Compound 3, half-maximal inhibitory concentration: 20200 nM
Compound 3: middle estimate off by 1.3-fold (0.11 log units), on the high side; the measured number falls inside the stated range.
By their numbers in this assay, from the lowest: compounds 3, 1 and 2 (each within the scatter of the next).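

Placing 1,3-benzothiazol-2-yl in place of phenyl on the aromatic nitrogen gives, in this assay, a 1.6-fold lower number from compound 2 to compound 3 (0.20 log units; within the scatter), so no change can be read. Earlier compounds varied only a substituent on the phenyl ring, whereas here the ring itself is replaced, and even a group with more heavy atoms, sulfur and hydrogen-bond acceptors leaves the number within the scatter. No outside evidence bears on this result. Still open, as far as these compounds go, is whether a smaller group on this nitrogen, such as methyl, or a phenyl ring bearing an amine or a carboxylic acid, would shift the number beyond the scatter.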